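Thiophene for pyridine beside the ring nitrogen

The compounds below may be only part of what the source reports. "The series", "measured", "known", "first", "only" and "open" are said of these compounds alone.

For compound 1 `Oc1cccc(-c2cc(-c3cccnc3)nc(-c3ccccc3Cl)c2)c1` the entry in an ADME assay on HEK293 cells (Homo sapiens) for cytotoxicity, read by CCK-8 assay and cell counting, with a stated time of 2 days (a higher number here means a weaker inhibitor, a lower number a stronger inhibitor), is "not determined" (no result reported), so no number is recorded for it. Within the data shown here, compound 2 `Oc1cccc(-c2cc(-c3ccc(Cl)cc3)nc(-c3cccnc3)c2)c1` gives 39500 nM in this assay, the only number in the set, so it stands alone with nothing to rank it against. Compound 3 `Oc1cccc(-c2cc(-c3ccc(Cl)cc3)nc(-c3ccsc3)c2)c1` differs from compound 2 by thiophen-3-yl in place of pyridin-3-yl on an aromatic carbon. Among the measured compounds shown here, with no measured step to lean on, the change from compound 2 to compound 3 is expected to stay within the usual scatter, so compound 3 is estimated at 35000 nM, between 15000 nM and 90000 nM, a step of a 1.1-fold lower number from compound 2 to compound 3 (0.05 log units; within the scatter) in this assay.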

Compound 3, half-maximal inhibitory concentration: 11200 nM
Compound 3: the middle estimate sits 3.1-fold (0.49 log units) above what was measured; measured number outside the range, below it.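

Among these compounds, at this position, next to the ring nitrogen, the group is not neutral in this assay: thiophen-3-yl in place of pyridin-3-yl gives a 3.5-fold lower number from compound 2 to compound 3 (0.55 log units; beyond the scatter) and so provides the first measured step in the set. The data offer no measurement that accounts for this step. As far as these compounds go, whether phenyl or furan-3-yl at this position would shift the number in the same way remains open. So does the effect of adding an amine or a carboxylic acid to the thiophen-3-yl ring.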